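Moving the halogen: compound 4 in the T-type channel assay

The source may report more compounds than this note shows. Statements on the series, on what has been measured and on what is new or still open speak of the compounds shown alone.

Of the compounds shown here, three sharing one core have been measured in an assay on HEK293 cells for inhibition of Voltage-dependent T-type calcium channel subunit alpha-1G (Homo sapiens), read by fluorescence, tested at 10 uM; a lower number here means less inhibition, a higher number more inhibition at the concentration tested (going by the name of the read-out). Compound 1 `CCCc1nc(-c2ccccc2)c(CNCCN2CCN(c3ccccc3Cl)CC2)o1` gives 60.1%, compound 2 `CCCc1nc(-c2ccccc2)c(CNCCN2CCN(c3ccccn3)CC2)o1` gives 48.1%, and compound 3 `CCCc1nc(-c2ccccc2)c(CNCCN2CCN(c3ccccc3C)CC2)o1` gives 51.3%. Compound 3 stands second highest of the three: its gap to compound 2 is within the scatter, and so is its gap to compound 1, so no order among them can be claimed. Among the compounds with values here, the only step that exceeds the scatter is a number 12 percentage points lower from compound 1 to compound 2 (beyond the scatter). Compound 4 `CCCc1nc(-c2ccccc2)c(CNCCN2CCN(c3cccc(Cl)c3)CC2)o1` differs from compound 3 as follows: 3-chlorophenyl in place of 2-methylphenyl on an amine nitrogen in a ring The step that bears on this change is a number 8.8 percentage points lower from compound 1 to compound 3 (within the scatter), which was within the scatter; with chlorine returning on the ring, the account expects compound 4 to sit near compound 3, with a step of a number 2.7 percentage points higher from compound 3 to compound 4 (within the scatter) in this assay, and the estimate for compound 4 is 54%, ranging from 38% to 70%.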

Compound 4, a percentage reported as inhibition, at one concentration (the size of the read-out at that concentration, not a potency): 51.2%
Estimate against measurement, compound 4: 2.8 percentage points above, and the stated range covers the measured number.
By their numbers in this assay, from the lowest: compounds 2, 4, 3 and 1 (each within the scatter of the next, the first and the last beyond it).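

In this assay, moving the chlorine from 2-chlorophenyl to 3-chlorophenyl gives a number 8.9 percentage points lower from compound 1 to compound 4 (within the scatter) and so cannot be read as a real change. The same holds for 3-chlorophenyl in place of 2-methylphenyl, a number 0.1 percentage points lower from compound 3 to compound 4 (within the scatter), and in place of pyridin-2-yl, a number 3.1 percentage points higher from compound 2 to compound 4 (within the scatter). Compound 4 therefore cannot be separated from any of the other three compounds, and this position accepts all of these aromatic groups without a change beyond the scatter from it. Going by these compounds, whether a methoxy group or a carboxylic acid on the phenyl ring would read differently remains open. Nothing available explains how these groups compare.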